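Geometry Change in a Polyacetylenic Diol Antifouling Series

The source may hold more compounds than are shown below. What is called first, only, known or untested is meant among the compounds shown, and "the series" means these compounds.

Measured compounds:
compound 1 `C#C/C=C\CCCC/C=C\C#CC#CCCCC#CC#C[C@H](COS(=O)(=O)O)OS(=O)(=O)O` gives 0.13 ug/mL
compound 2 `C#C/C=C\CCCC(O)/C=C\C#CC#CCCCC#CC#CC(O)CO` gives 1.3 ug/mL

Both compounds were tested in a functional assay on the whole organism with Amphibalanus amphitrite as the target; on this read-out higher numbers stand for an effect only at larger amounts of compound and lower numbers for an effect already at smaller amounts. Compound 2 `C#C/C=C\CCCC(O)/C=C\C#CC#CCCCC#CC#CC(O)CO` stands at the higher of the two numbers, and its nearest neighbour, compound 1 `C#C/C=C\CCCC/C=C\C#CC#CCCCC#CC#C[C@H](COS(=O)(=O)O)OS(=O)(=O)O`, lies at a lower number, a gap that is beyond the scatter of repeated measurements. Compound 2 therefore acts only at larger amounts than compound 1 in this assay.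

Compound 3 `C#C/C=C\CCCC(O)/C=C/C#CC#CCCCC#CC#CC(O)CO` has not yet been measured. It differs from compound 2 in a single respect: the two compounds have the same atoms and bonds; at least one stereo element is drawn with a configuration in one of them and without one in the other: 1 of 4 stereo elements differ; a double bond is drawn Z in compound 2 and E in compound 3. Nothing leaves and nothing enters; only the drawn geometry of one double bond is changed. For the measured compounds named here, no pair of measured compounds shows what such a change does in this assay, so there is no step to lean on. The author expects compound 3 to stay close to compound 2, with a step of no change at the digits printed from compound 2 to compound 3 (within the scatter), which is within the scatter and not a change in either direction beyond it. The estimated value for compound 3 is 1.3 ug/mL, with a range from 0.5 ug/mL to 3.5 ug/mL.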

Compound 3, concentration for half-maximal effect: 0.13 ug/mL
The estimate for compound 3 lay 10-fold (1.00 log units) above the measured number; measured number below the stated range.
By their numbers in this assay, from the lowest: compounds 1 and 3 (each within the scatter of the next); then compound 2.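

In this assay, for the compounds shown here, the earlier compounds offered no pair that isolated the geometry of a double bond. Changing the drawn geometry of this one double bond from Z to E, with nothing leaving and nothing entering, gives a 10-fold lower number from compound 2 to compound 3 (1.00 log units; beyond the scatter). Geometry at this position is therefore not a silent feature of the diol series: the whole-organism read-out separates two compounds with the same atoms and bonds, and one caution applies to how this single step is read: the fact that one of compounds 2 and 3 is drawn with a defined configuration and the other without, at the place where they differ

The compounds shown leave open whether the other double bond in the chain responds to a change of geometry in the same way, and whether the step from Z to E would persist in a compound carrying sulfate esters, as compound 1 does. As far as these compounds go, they also do not show what would happen at this position if the hydroxyl groups of the diol were replaced by acetate esters or methyl ethers, so the reach of this single step beyond compound 2 and compound 3 remains unknown.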